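The compounds below may be only part of what the source reports. "The series", "measured", "known", "first", "only" and "open" are said of these compounds alone.

Measured compounds: compound 2 `CCN(CC)CCCOc1ccc2c(c1)C(=O)N(C)CC2` and compound 1 `CN1CCN(CCCOc2ccc3c(c2)C(=O)N(C)CC3)CC1`. In an assay on cerebellum for displacement of a labelled ligand from histamine H1 receptor (Cavia porcellus), read by scintillation counting, with a stated time of 60 min (a lower number here means a stronger inhibitor, a higher number a weaker inhibitor), compound 2 gives 542 nM; compound 1 gives 706 nM.

Compound 2 gives the lower of the two numbers, but the step from compound 1 to compound 2 is small a 1.3-fold lower number from compound 1 to compound 2 (0.11 log units; within the scatter), so the two sit within the scatter. Compound 3 `CC1CCCCN1CCCOc1ccc2c(c1)C(=O)N(C)CC2` carries 2-methylpiperidin-1-yl in place of diethylamino on a saturated chain carbon, three bonds along the chain from an oxygen on an aromatic ring. Among the compounds with values here, the one measured step exchanges a cyclic amine for an acyclic one and stays within the scatter; the return to a cyclic amine in compound 3 is the only guide, so no step beyond the scatter is expected in this assay. Compound 3 is therefore estimated at 500 nM, range 200 nM to 1300 nM, an expected step of a 1.1-fold lower number from compound 2 to compound 3 (0.04 log units; within the scatter).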

Compound 3, inhibition constant: 165 nM
Estimate against measurement, compound 3: 3.0-fold (0.48 log units) above, and the stated range ends above it.
By their numbers in this assay, from the lowest: compound 3; then compounds 2 and 1 (each within the scatter of the next).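

In this assay the position on the saturated chain carbon proves sensitive to the amine: 2-methylpiperidin-1-yl gives a 3.3-fold lower number from compound 2 to compound 3 (0.52 log units; beyond the scatter) and a 4.3-fold lower number from compound 1 to compound 3 (0.63 log units; beyond the scatter) as steps beyond the scatter. A ring on this carbon is not enough on its own, as compound 1 also carries one and stays within the scatter of compound 2. Nothing measured bears on the reason for these steps.

Still open, on these data alone, is whether the change belongs to the ring or to its methyl group, which piperidin-1-yl would separate. Also open, as far as these compounds go, is how a longer chain to the amine would read.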